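Working notes: compound 3 to compound 4

The source may hold more compounds than are shown below. What is called first, only, known or untested is meant among the compounds shown, and "the series" means these compounds.

- compound 1 `C#CCOc1ccc2c(=O)c(-c3cc(OC)c(OC)cc3OC)coc2c1` gives 8050 nM
- compound 2 `COc1cc(OC)c(-c2coc3cc(OCc4ccc([N+](=O)[O-])cc4)ccc3c2=O)cc1OC` gives > 10000 nM, a limit of the assay and not a number
- compound 3 `COc1cc(OC)c(-c2coc3cc(OCc4ccccc4C(F)(F)F)ccc3c2=O)cc1OC` gives 4760 nM

In a functional assay on HCT-116 cells (Homo sapiens) for antiproliferative activity, read by MTT assay, with a stated time of 24 h (on this read-out higher numbers stand for weaker inhibition and lower numbers for stronger inhibition), compound 3 gives 4760 nM and compound 1 gives 8050 nM, and the two stand together: a 1.7-fold lower number from compound 1 to compound 3 (0.23 log units; within the scatter). Among the measured compounds shown here, measured against the limit of compound 2, the picture is an at least 2.1-fold lower number from compound 2 to compound 3 (0.32 log units; beyond the scatter), the only step here that clears the scatter.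

Compound 4 `COc1cc(OC)c(-c2coc3cc(OCc4ccccc4C#N)ccc3c2=O)cc1OC` keeps the shared core and carries cyano in place of trifluoromethyl on an aromatic carbon, ortho to a large group (cyano in place of trifluoromethyl on an aromatic carbon). For the measured compounds named here, no measured step makes this swap. The three measured steps each exchange the whole group on the saturated chain carbon, so they bear on it only loosely. The third of them is an at least 1.2-fold higher number from compound 1 to compound 2 (0.09 log units; that floor lies within the scatter). The swap in compound 4 leaves that group's ring in place, so a step smaller than an at least 2.1-fold lower number from compound 2 to compound 3 (0.32 log units; beyond the scatter) is expected, with a slight lean towards weaker inhibition.

The expected step is a 1.3-fold higher number from compound 3 to compound 4 (0.10 log units; within the scatter), which means no change beyond the scatter is expected in this assay. Compound 4 is estimated at 6000 nM with an expected range of 2500 nM to 10000 nM around it.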

Compound 4, half-maximal inhibitory concentration: > 10000 nM
Compound 4 ended at the assay's limit; the forecaster's own chance of this, stated with the estimate: 20%; middle value at least 1.6-fold (0.22 log units) from the limit.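

In this assay, exchanging trifluoromethyl for cyano on an aromatic carbon, ortho to a large group, gives an at least 2.1-fold higher number from compound 3 to compound 4 (0.32 log units; beyond the scatter). Among the compounds shown here, a change confined to this one substituent, with the rest of the benzyl group kept, therefore moves the read-out beyond the scatter, something the earlier steps could not show, as each of them exchanged the whole group on the saturated chain carbon. The comparison with the ethynyl compound adds only an at least 1.2-fold higher number from compound 1 to compound 4 (0.09 log units; that floor lies within the scatter), and the values of compound 2 and compound 4 are both limits of the assay, so the step between them cannot be read: the limit of > 10000 nM in this assay, at which 2 of the 4 values shown sit.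

As far as these compounds go, how far compound 4 lies past its limit stays open, so the step from the 2-(trifluoromethyl)benzyl group to the 2-cyanobenzyl group has a floor and no measured size. From the compounds shown here alone, it also stays open whether the number held by compound 3 is particular to trifluoromethyl, a question that a chlorine atom, a methoxy group or an aminomethyl group on the same aromatic carbon would address.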